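A few compounds are considered here, and "the series" means these few. Any claim that something is new, unique, unknown or untested is made for them only; others in the source may bear on it.

Series so far, read in a functional assay on MCF7 cells (Homo sapiens) for cytotoxicity, read by colorimetric assay and MTT assay; a higher number here means a weaker inhibitor, a lower number a stronger inhibitor

compound 1 `COc1ccc(-c2cc3c(OC)ccc(OC)c3nc2O)cc1` gives 10000 nM
compound 2 `COc1cc(OC)c2cc(-c3ccc(OCc4ccccc4)cc3)c(O)nc2c1` gives 10000 nM
compound 3 `COc1ccc(-c2cc3c(OC)cc(OC)cc3n(CC#N)c2=O)cc1` gives 10000 nM

Compound 3 stands level with compound 1 and compound 2, so the three show no spread to read. Compound 4 `COc1ccc(-c2cc3c(OC)cc(OC)cc3n(CC(=O)OCc3ccccc3)c2=O)cc1` has benzyloxycarbonyl in place of cyano on a saturated chain carbon bound to an aromatic nitrogen. No measured pair sizes such a change. With no spread among these three, a small step toward a stronger inhibitor in this assay is expected, or none beyond the scatter. The estimated value for compound 4 is 7000 nM (expected range 2500 nM to 12000 nM). This estimate means a 1.4-fold lower number from compound 3 to compound 4 (0.15 log units; within the scatter) as the expected step.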

Compound 4, half-maximal inhibitory concentration: 10000 nM
Beside the measured number, compound 4's estimate is 1.4-fold (0.15 log units) below it, and the stated range covers the measured number.
By their numbers in this assay, from the lowest: compounds 1, 2, 3 and 4 (each within the scatter of the next).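

In this assay, going by these compounds alone, benzyloxycarbonyl in place of cyano on a saturated chain carbon bound to an aromatic nitrogen gives no change at the digits printed from compound 3 to compound 4 (within the scatter), the only measured step at this position. The entering group brings 10 heavy atoms and a six-membered aromatic ring of carbon only, against 2 heavy atoms and no ring in cyano, yet compound 4 stays at 10000 nM, level with compound 3. Nothing measured here accounts for this result.

On these data alone, whether an amine or a carboxylic acid on this chain would shift the number remains open.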